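A few compounds are considered here, and "the series" means these few. Any claim that something is new, unique, unknown or untested is made for them only; others in the source may bear on it.

Compound 1 `Cc1cccc(-c2cnc(N)nc2-c2ccccc2)c1` sits at a limit of an assay on CHO cells for displacement of a labelled ligand from adenosine receptor A1 (Homo sapiens), read by scintillation counting, with a stated time of 1 h, tested at 1 uM (on this read-out lower numbers stand for less inhibition and higher numbers for more inhibition at the one concentration tested (going by the name of the read-out)), reported as > 80%.
Compound 2 `Nc1ncc(-c2ccc(OCc3ccccc3)c(Cl)c2)c(-c2ccccc2)n1` gives 38% in this assay.
Compound 3 `CCCCC(=O)Nc1ncc(-c2cccc(Cl)c2)c(-c2ccccc2)n1` gives 52% in this assay.

Of the two results reported as numbers, compound 3 is the higher, and compound 2 lies lower by a gap that goes beyond the usual scatter of repeated measurements. The third result, that of compound 1, is a limit of the assay rather than a number (the limit of > 80% in this assay, at which 1 of the 3 values shown sits).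

Compound 4 `CNc1ncc(-c2cccc(Cl)c2)c(-c2ccccc2)n1` has not yet been measured in this assay. It differs from compound 3 in a single place: methyl in place of butylcarbonyl on a nitrogen on an aromatic ring. The butylcarbonyl chain is gone, and a lone methyl stands in its place on the nitrogen on the aromatic ring, so that the (butylcarbonyl)amino of compound 3 becomes a methylamino in compound 4.

No measured pair of compounds shown here differs in only one place, so the size of this kind of change has not been seen directly. The expectation is a modest upward step in this assay, though one that may well fall within the scatter. Compound 4 is estimated to give about 60%, with a likely range from 35% to 85%. This estimate means an expected step of a number 8 percentage points higher from compound 3 to compound 4 (within the scatter).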

Compound 4, a percentage reported as inhibition, at one concentration (the size of the read-out at that concentration, not a potency): 75%
Beside the measured number, compound 4's estimate is 15 percentage points below it, and the stated range covers the measured number.
By their numbers in this assay, from the lowest: compound 2; then compound 3; then compound 4. At a limit, above all of these: compound 1.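

In this assay, for the compounds shown here, this pair gives the first direct look at what the group on the nitrogen on the aromatic ring does, since everything else in the two structures is shared: with methyl in place of butylcarbonyl, the result comes out a number 23 percentage points higher from compound 3 to compound 4 (beyond the scatter). The change removes six heavy atoms, including the carbonyl, and puts back one, so neither the butylcarbonyl chain as a whole nor its carbonyl is required for inhibition at the one concentration tested in this pair. Nothing measured here gives a reason for the step.

The compounds shown leave open whether the step follows from losing the carbonyl or from shortening the chain, and an acetyl group and a plain butyl group on the same nitrogen would begin to separate those two readings. Also open, as far as these compounds go, is how far the trend runs along this position, for example with an ethyl group, with a second methyl giving a dimethylamino group, or with a longer chain, and whether the same swap gives a similar step when the rest of the molecule changes.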